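The compounds below may be only part of what the source reports. "The series", "measured", "known", "first", "only" and "open" are said of these compounds alone.

Compound 1, `COc1cccc(OC)c1OCCNCCOc1ccccc1OCc1ccccc1Cl`, compound 2, `COc1cccc(OC)c1OCCNCCOc1ccccc1OCc1ccc(Cl)cc1`, and compound 3, `COc1cccc(OC)c1OCCNCCOc1ccccc1OCc1ccc(C)cc1`, share one core and differ only in the group on a saturated chain carbon bound to an oxygen on an aromatic ring. In a functional assay on thoracic aorta for antagonist activity at Alpha-1D adrenergic receptor (Rattus norvegicus) (on this read-out higher numbers stand for higher potency (the scale is a negative logarithm) and lower numbers for lower potency), compound 1 gives 8.59, compound 2 gives 9.11, and compound 3 gives 9.12. Compound 3 thus stands highest of the three numbers, though its gap to compound 2 is within the scatter, while its gap to compound 1 is beyond it. Compound 4, `COc1ccccc1COc1ccccc1OCCNCCOc1c(OC)cccc1OC`, is not yet measured; the change from compound 3 is 2-methoxyphenyl in place of 4-methylphenyl on a saturated chain carbon bound to an oxygen on an aromatic ring. For the measured compounds named here, two measured steps bear on this: a number 0.52 log units higher from compound 1 to compound 2 (beyond the scatter) and a number 0.53 log units higher from compound 1 to compound 3 (beyond the scatter), both modest gains when the 2-chlorophenyl gave way to a 4-substituted phenyl. Compound 4 returns to a 2-substituted phenyl, so the step is expected to run the other way, likely by a comparable amount; the change of methyl to methoxy offers no measured guide, as a number 0.01 log units higher from compound 2 to compound 3 (within the scatter) was within the scatter. Compound 4 is therefore expected to give a step of a number 0.42 log units lower from compound 3 to compound 4 (beyond the scatter) in this assay, an estimated 8.7, with a range of 8.3 to 9.1.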

Compound 4, negative logarithm of the antagonist equilibrium constant: 8.86
Beside the measured number, compound 4's estimate is 0.16 log units below it, within the range that was stated.
By their numbers in this assay, from the lowest: compounds 1, 4, 2 and 3 (each within the scatter of the next, the first and the last beyond it).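

In this assay, the 2-methoxyphenyl group cannot be told apart from any of the three groups tested before it at this position, with a number 0.26 log units lower from compound 3 to compound 4 (within the scatter), a number 0.25 log units lower from compound 2 to compound 4 (within the scatter) and a number 0.27 log units higher from compound 1 to compound 4 (within the scatter). The earlier compounds shown here separated the 2-chlorophenyl group from the 4-chlorophenyl and 4-methylphenyl groups, but compound 4 sits within the scatter of both sides of that gap, so it joins neither side and the substituent's ring position alone does not sort these compounds. The exchange adds an oxygen and a hydrogen-bond acceptor to the group that leaves, and this produces no step beyond the scatter from compound 3. No measurement here explains why these groups at this position give the numbers they do.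

The compounds shown leave open whether 4-methoxyphenyl would stand with compound 2 and compound 3, and so whether methoxy behaves differently from chloro when the ring position changes. They also leave open how an unsubstituted phenyl or a pyridyl ring would compare at this position.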